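Amide-type nitrogen substituent series, cytotoxicity on gastric cells

The source may hold more compounds than are shown below. What is called first, only, known or untested is meant among the compounds shown, and "the series" means these compounds.

Measured compounds:
compound 1, `COC(=O)CCNC(=O)Cn1cc(C2=C(c3c[nH]c4ccccc34)C(=O)N(C)C2=O)c2ccccc21`, 44900 nM in a functional assay on BGC-823 cells (Homo sapiens) for cytotoxicity, read by MTT assay, with a stated time of 24 h; on this read-out lower numbers stand for stronger inhibition and higher numbers for weaker inhibition
compound 2, `COC(=O)[C@@H](CC(C)C)NC(=O)Cn1cc(C2=C(c3c[nH]c4ccccc34)C(=O)N(C)C2=O)c2ccccc21`, 45500 nM
compound 3, `COC(=O)[C@@H](C)NC(=O)Cn1cc(C2=C(c3c[nH]c4ccccc34)C(=O)N(C)C2=O)c2ccccc21`, 60400 nM

All three compounds share one core and differ only in the group on the amide-type nitrogen. Compound 3 has the highest number of the three, but its steps to the other two are small: a 1.3-fold higher number from compound 1 to compound 3 (0.13 log units; within the scatter) and a 1.3-fold higher number from compound 2 to compound 3 (0.12 log units; within the scatter), so no order among the three can be read from these numbers.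

Compound 4, `CC[C@H](C)[C@@H](NC(=O)Cn1cc(C2=C(c3c[nH]c4ccccc34)C(=O)N(C)C2=O)c2ccccc21)C(=O)OC`, is not yet measured. Its difference from compound 3 is sec-butyl in place of methyl on a saturated chain carbon bound to an amide-type nitrogen and a carbonyl carbon. Among the compounds with values here, the step that bears most closely on this is the one between compound 2 and compound 3, where isopropyl and hydrogen are exchanged on the saturated chain carbon two bonds along the chain from the amide-type nitrogen and the carbonyl carbon: a 1.3-fold higher number from compound 2 to compound 3 (0.12 log units; within the scatter). The step of a 1.0-fold higher number from compound 1 to compound 2 (0.01 log units; within the scatter), which also reshapes the chain carried by the amide-type nitrogen, is likewise within the scatter. Neither suggests that the size of the branch at this position moves the number beyond the scatter, so for compound 4 a step of a 1.2-fold lower number from compound 3 to compound 4 (0.07 log units; within the scatter) is expected, that is, no change beyond the scatter. The estimate for compound 4 is therefore 52000 nM, with a range from 26000 nM to 104000 nM.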

Compound 4, half-maximal inhibitory concentration: > 100000 nM
Compound 4: no number, only a limit; the forecaster's own chance of this, stated with the estimate: 10%; middle value at least 1.9-fold (0.28 log units) from the limit.
By their numbers in this assay, from the lowest: compounds 1, 2 and 3 (each within the scatter of the next). At a limit, above all of these: compound 4.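

Sec-butyl on the saturated chain carbon bound to an amide-type nitrogen and a carbonyl carbon gives the first steps in the series to pass the scatter: replacing isobutyl at this carbon gives (an at least 2.1-fold higher number from compound 2 to compound 4 (0.34 log units; beyond the scatter)), and the comparison with the unbranched starting chain gives (an at least 2.2-fold higher number from compound 1 to compound 4 (0.34 log units; beyond the scatter)). Within the data shown here, this position is therefore less indifferent to the group it carries than the earlier steps, all within the scatter, could show, although the floor of the step from methyl (an at least 1.6-fold higher number from compound 3 to compound 4 (0.21 log units; that floor lies within the scatter)) does not establish this by itself. In this assay compound 4 gives > 100000 nM as a limit and not as a number: the limit of > 100000 nM in this assay, at which 1 of the 4 values shown sits.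

From the compounds shown here alone, the true size of all three steps stays open, since only their floors can be read. Also open, going by these compounds, is whether the same shift follows only sec-butyl, with its defined stereocentre, or also a phenyl or benzyl group at this carbon, and whether a free carboxylic acid in place of the methoxycarbonyl group would alter the picture.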